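The source may report more compounds than this note shows. Statements on the series, on what has been measured and on what is new or still open speak of the compounds shown alone.

Of the compounds shown here, two sharing one core have so far been measured in a functional assay on LNCaP cells (Homo sapiens) for antiproliferative activity, read by MTT assay, with a stated time of 96 h; on this read-out higher numbers stand for weaker inhibition and lower numbers for stronger inhibition. Compound 1 `CCN1CCN(c2ccc3nnnc(Nc4cccc(OC(F)(F)F)c4)c3n2)CC1` gives 14300 nM, the higher of the two numbers. Compound 2 `FC(F)(F)Oc1cccc(Nc2nnnc3ccc(N4CCC(N5CCCCC5)CC4)nc23)c1` gives 4900 nM, a clearly lower number that lies beyond the scatter of repeat measurements. The unmeasured compound 3 `FC(F)(F)Oc1cccc(Nc2nnnc3ccc(N4CCC(N5CCCC5)CC4)nc23)c1` keeps the core of compound 1 but carries a different group there: 4-(pyrrolidin-1-yl)piperidin-1-yl in place of 4-ethylpiperazin-1-yl on an aromatic carbon. Among the measured compounds shown here, the entering group is closely related to the one found in compound 2, differing only in the size of the ring attached to the piperidine. For the measured compounds named here, no step between measured compounds is available to calibrate this change directly, so the expectation leans on compound 2, whose related group gives 4900 nM in this assay. Compound 3 is therefore expected to show a moderate step of a 2.9-fold lower number from compound 1 to compound 3 (0.46 log units; beyond the scatter) toward stronger inhibition. The estimated value for compound 3 is 5000 nM, with a likely range from 2000 nM to 15000 nM.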

Compound 3, half-maximal inhibitory concentration: 10700 nM
Compound 3: the middle estimate sits 2.1-fold (0.33 log units) below what was measured; measured number inside the range.
By their numbers in this assay, from the lowest: compound 2; then compounds 3 and 1 (each within the scatter of the next).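

Placing 4-(pyrrolidin-1-yl)piperidin-1-yl instead of 4-ethylpiperazin-1-yl on this aromatic carbon gives, in this assay, a 1.3-fold lower number from compound 1 to compound 3 (0.13 log units; within the scatter), so this exchange does not separate the two compounds on this read-out. The second step is more informative: pyrrolidin-1-yl in place of piperidin-1-yl on the saturated ring carbon gives a 2.2-fold higher number from compound 2 to compound 3 (0.34 log units; beyond the scatter), which shows that a piperidine carrying a second ring is not enough on its own and that the identity of this outer ring matters among these compounds. Nothing available here explains either result.

The compounds shown leave open how a seven-membered azepan-1-yl ring would read on that same saturated ring carbon. They also leave open what a morpholin-4-yl or dimethylamino group would do there.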